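Adding a hydroxy to compound 2: a cryptophycin-type pair

A few compounds are considered here, and "the series" means these few. Any claim that something is new, unique, unknown or untested is made for them only; others in the source may bear on it.

Two compounds of a shared macrocyclic core were tested in a functional assay on A549 cells (Homo sapiens) for antiproliferative activity, read by MTT assay, with a stated time of 72 h; on this read-out lower numbers stand for stronger inhibition and higher numbers for weaker inhibition. Compound 1 `CC[C@H](C)[C@H]1C(=O)N[C@H](Cc2ccc(O)c(OC)c2)C(=O)N[C@@H](C(C)(C)O)C(=O)O[C@H](c2ccccc2)[C@H](C)/C=C/C=C(\C)[C@H](OC)C[C@@H]2O[C@@]2(C)C(=O)N1C` gives 3.7 nM in this assay. Compound 2 `CC[C@H](C)[C@H]1C(=O)N[C@H](Cc2cc(Cl)c(O)c(Cl)c2)C(=O)N[C@@H](C(C)C)C(=O)O[C@H](c2ccccc2)[C@H](C)/C=C/C=C(\C)[C@H](OC)C[C@@H]2O[C@@]2(C)C(=O)N1C` gives 3.2 nM in this assay, the lowest of the two numbers, though its gap to compound 1 lies within the scatter of repeated measurements, so no order between the two can be drawn. Compound 3 `CC[C@H](C)[C@H]1C(=O)N[C@H](Cc2cc(Cl)c(O)c(Cl)c2)C(=O)N[C@@H](C(C)(C)O)C(=O)O[C@H](c2ccccc2)[C@H](C)/C=C/C=C(\C)[C@H](OC)C[C@@H]2O[C@@]2(C)C(=O)N1C` has not yet been measured. It differs from compound 2 in one place: hydroxy in place of hydrogen on a saturated chain carbon bound to two saturated chain carbons and a saturated ring carbon. Among the compounds with values here, no measured pair in this set isolates the same change, so the expected step rests on the two numbers alone. The step from compound 2 to compound 3 in this assay is expected to be small, a 1.3-fold higher number from compound 2 to compound 3 (0.10 log units; within the scatter), not clearly beyond the scatter in either direction. For compound 3 the estimate in this assay is 4 nM, with a range from 1.5 nM to 12 nM.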

Compound 3, half-maximal inhibitory concentration: 13.1 nM
Compound 3: middle estimate off by 3.3-fold (0.52 log units), on the low side, outside the stated range (above it).
By their numbers in this assay, from the lowest: compounds 2 and 1 (each within the scatter of the next); then compound 3.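

In this assay, within the data shown here, with the 3,5-dichloro-4-hydroxyphenyl group held fixed, changing isopropyl to 1-hydroxy-1-methylethyl gives a 4.1-fold higher number from compound 2 to compound 3 (0.61 log units; beyond the scatter), so this position does not accept the added hydroxy without a loss of activity, a cost the earlier compounds could not show. With the 1-hydroxy-1-methylethyl group held fixed, 3,5-dichloro-4-hydroxyphenyl in place of 4-hydroxy-3-methoxyphenyl gives a 3.5-fold higher number from compound 1 to compound 3 (0.55 log units; beyond the scatter), so the aryl group also matters once that hydroxy is present. Nothing available here explains either step.

Going by these compounds, whether the hydroxy step would have the same size with 4-hydroxy-3-methoxyphenyl in place remains open. On these data alone, it is also open how a methoxy or an amine in place of the hydroxy on that saturated chain carbon would read in this assay.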